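From 2-cyanobenzyl to 4-cyanobenzyl: an expected small step

A few compounds are considered here, and "the series" means these few. Any claim that something is new, unique, unknown or untested is made for them only; others in the source may bear on it.

Compound 1 `COC(=O)[C@H](CCSC)NC(=O)c1ccc(CNCc2c[nH]cn2)cc1-c1ccccc1C`: 25 uM
Compound 2 `CSCC[C@H](NC(=O)c1ccc(NCc2cncn2Cc2ccccc2C#N)cc1-c1ccccc1)C(=O)O`: > 10 uM

Of the compounds shown here, two have been measured in a functional assay on NIH3T3 cells (Mus musculus); on this read-out lower numbers stand for an effect already at smaller amounts and higher numbers for an effect only at larger amounts of compound. Compound 1 gives 25 uM. For compound 2 the assay reports only a limit, > 10 uM, so its true value is not known. Compound 2 thus stands at the limit of > 10 uM in this assay, at which 1 of the 2 values shown sits, and nothing more precise can be said of it.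

Compound 3 `CSCC[C@H](NC(=O)c1ccc(NCc2cncn2Cc2ccc(C#N)cc2)cc1-c1ccccc1)C(=O)O` has the same atoms as compound 2, joined differently: 4-cyanophenyl in place of 2-cyanophenyl on a saturated chain carbon bound to an aromatic nitrogen. Within the data shown here, no pair of measured compounds differing in a single place is available, so how large such a step tends to be in this assay is unknown from these data alone.

The step from compound 2 to compound 3 is expected to be small, none beyond the usual scatter, as a step that the limit leaves unreadable from compound 2 to compound 3. Compound 3 is therefore estimated at about 20 uM, between 8 uM and 60 uM, and it may well again come back only as a limit.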

Compound 3, concentration for half-maximal effect: > 10 uM
Compound 3: no number, only a limit; the forecaster's own chance of this, stated with the estimate: 70%; the middle value is on the limit's open side.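

Compound 3 also comes back only as a limit, so the step from compound 2 to compound 3 cannot be read: the limit of > 10 uM in this assay, at which 2 of the 3 values shown sit.

The compounds shown leave open the true value of each compound and whether 4-cyanobenzyl in place of 2-cyanobenzyl changes the effect at all.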